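A few compounds are considered here, and "the series" means these few. Any claim that something is new, unique, unknown or untested is made for them only; others in the source may bear on it.

Working notes on the series, read in an ADME assay on the whole organism (strain Sprague-Dawley) for pharmacokinetics, with Rattus norvegicus as the target, read by LC-MS, using cassette dosing, at a dose of 0.5 mg/kg by the intravenous route; a higher number here means faster removal of the compound, a lower number slower removal. Compound 1 (`COCC1=C[C@@](C)(c2cc(NC(=O)c3ccc(C#N)cn3)ccc2F)N=C(N)O1`) gives 12.9 mL/min/kg, compound 2 (`C[C@@]1(c2cc(NC(=O)c3ncc(C#N)cc3Cl)ccc2F)C=C(CF)OC(N)=N1`) gives 30.6 mL/min/kg, and compound 3 (`C[C@@]1(c2cc(NC(=O)c3ncc(OCF)nc3N)ccc2F)C=C(CF)OC(N)=N1`) gives 45.3 mL/min/kg. Compound 3 lies within the scatter of compound 2 and beyond the scatter of compound 1, which has the lower number.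

Compound 4 (`C[C@@]1(c2cc(NC(=O)c3coc(CF)n3)ccc2F)C=C(CF)OC(N)=N1`) has not been measured. It keeps the shared core of compound 3 and differs on a carbonyl carbon, where 2-(fluoromethyl)-1,3-oxazol-4-yl stands in place of 3-amino-5-(fluoromethoxy)pyrazin-2-yl (2-(fluoromethyl)-1,3-oxazol-4-yl in place of 3-amino-5-(fluoromethoxy)pyrazin-2-yl on a carbonyl carbon).

Among the compounds with values here, one measured step bears directly on this place: a 1.5-fold higher number from compound 2 to compound 3 (0.17 log units; within the scatter), an exchange on the same carbonyl carbon that stays within the scatter. Within the data shown here, compound 1 differs from compound 3 in more than one place and gives no clean step. Among the measured compounds shown here, with only that single exchange as a guide, no step beyond the scatter is expected in this assay. The expected step, within the scatter, is a 1.2-fold lower number from compound 3 to compound 4 (0.08 log units; within the scatter). No measured compound carries a five-membered aromatic ring on this carbonyl carbon, and the range is kept wide for that reason. For compound 4 the estimate is 38 mL/min/kg, with an expected range of 20 mL/min/kg to 70 mL/min/kg.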

Compound 4, clearance: 55 mL/min/kg
For compound 4 the middle estimate is 1.4-fold (0.16 log units) below the measured one; the range from low to high includes it.
By their numbers in this assay, from the lowest: compound 1; then compounds 2, 3 and 4 (each within the scatter of the next).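

In this assay, placing 2-(fluoromethyl)-1,3-oxazol-4-yl on the carbonyl carbon in place of 3-amino-5-(fluoromethoxy)pyrazin-2-yl gives a 1.2-fold higher number from compound 3 to compound 4 (0.08 log units; within the scatter), while placing it there in place of 3-chloro-5-cyanopyridin-2-yl gives a 1.8-fold higher number from compound 2 to compound 4 (0.25 log units; within the scatter). This position now carries a five-membered aromatic ring as well as two six-membered ones, and the change to a group with fewer heavy atoms and no hydrogen-bond donor leaves compound 4 within the scatter of both neighbours, so among compounds 2, 3 and 4 no exchange at this place shows a real change in clearance. Nothing at hand accounts for this flat reading.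

Still open, from the compounds shown here alone, is whether a group of another kind on this carbonyl carbon, such as a longer alkyl chain or a carboxylic acid, would move the number beyond the scatter. Compound 1 differs from the other compounds in more than one place, including a methoxymethyl group in place of fluoromethyl, so the shares of that group and of the group on its carbonyl carbon in its value of 12.9 mL/min/kg remain unseparated.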